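Chloro-to-hydrogen step on the pendant ring in two cores

This account rests on a few compounds, and the source may have more. Where it says the series, first, only, none or still open, it means among the compounds named here.

Measured so far:
compound 1, `COc1cc(/C=C/C(=O)C2=C(/C=C/c3ccc(O)c(OC)c3)NC(=O)NC2c2c(Cl)cccc2Cl)ccc1O`, in a functional assay, with a stated time of 20 min, tested at 10 uM; a higher number here means a stronger effect of the compound at the concentration tested, a lower number a weaker effect: 20%
compound 2, `COc1cc(/C=C/C(=O)C2=C(/C=C/c3ccc(O)c(OC)c3)NC(=O)NC2c2ccccc2Cl)ccc1O`: 23%
compound 3, `COc1cc(/C=C/C(=O)C2=C(/C=C/c3ccc(O)c(OC)c3)NC(=S)NC2c2c(Cl)cccc2Cl)ccc1O`: 20.2%

Compound 4, `COc1cc(/C=C/C(=O)C2=C(/C=C/c3ccc(O)c(OC)c3)NC(=S)NC2c2ccccc2Cl)ccc1O`, has not been measured.

Within the data shown here, the one step seen so far is hydrogen in place of chloro on an aromatic carbon, which gave a number 3 percentage points higher from compound 1 to compound 2 (within the scatter). The two values of compound 1 and compound 2 thus sit within the scatter of each other, and no order between them is claimed.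

Compound 3 carries a second core; the difference between the two cores is not broken down here. The values of compound 1 and compound 3 lie within the scatter of each other as well.

Compound 4 stands to compound 3 as compound 2 stands to compound 1: hydrogen in place of chloro on an aromatic carbon. The place of the change is the same, word for word, in both pairs, so this is the same change on the second core.

The step from compound 3 to compound 4 is expected to be a number 2.8 percentage points higher from compound 3 to compound 4 (within the scatter), of the same small size as the earlier one, because a number 3 percentage points higher from compound 1 to compound 2 (within the scatter) stayed within the scatter. Compound 4 is therefore estimated at 23%, between 13% and 33%.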

Compound 4, a percentage reported as activity, at one concentration (the size of the read-out at that concentration, not a potency): 21.2%
For compound 4 the middle estimate is 1.8 percentage points above the measured one; the measured number falls inside the stated range.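

In this assay, the 2,6-dichlorophenyl to 2-chlorophenyl change on the second core gives a number 1 percentage points higher from compound 3 to compound 4 (within the scatter), and the two steps for this change cannot be told apart: the same change on two cores in this assay, a number 3 percentage points higher (within the scatter) from compound 1 to compound 2 and a number 1 percentage points higher (within the scatter) from compound 3 to compound 4, 2 percentage points apart, within the scatter of two such steps

The change therefore carries from one core to the other only in a limited sense: on neither core does the step rise above the scatter. This does not show that the change has a real effect on the read-out in either core, and two small steps at one tested concentration cannot establish that a measurable effect would transfer between cores.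

The compounds shown leave open what happens when the remaining chloro on the pendant ring is also replaced by hydrogen, or when an amine or a carboxylic acid stands on that ring instead. Also open, on these data alone, is whether the same flat picture would hold on a core other than these two.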